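The source may report more compounds than this note shows. Statements on the series, on what has been measured and on what is new or still open speak of the compounds shown alone.

Measured compounds:
compound 1, `O=C(O)c1ccccc1-c1ccc(CCc2ncc(CC3CCCC3)[nH]2)cc1`: 7.9 nM
compound 2, `O=C(O)c1ccccc1-c1ccc(CCc2ncc(Cc3cccc(F)c3)[nH]2)cc1`: 7.9 nM
compound 3, `CC(C)(C)CCc1cnc(CCc2ccc(-c3ccccc3C(=O)O)cc2)[nH]1`: 6.2 nM

In an in vitro functional assay on cells for agonist activity at Bombesin receptor subtype-3 (Mus musculus), read by luminescence and calcium flux (on this read-out higher numbers stand for an effect only at larger amounts of compound and lower numbers for an effect already at smaller amounts), compound 1 gives 7.9 nM, level at the digits shown with compound 2, which gives 7.9 nM. The step of no change at the digits printed from compound 1 to compound 2 (within the scatter) lies within the scatter, as does the step of a 1.3-fold lower number from compound 1 to compound 3 (0.11 log units; within the scatter) to compound 3, so all three values sit in one band and none can be told apart from another.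

Compound 4, `N#Cc1ccccc1Cc1cnc(CCc2ccc(-c3ccccc3C(=O)O)cc2)[nH]1`, differs from compound 1 in one place: 2-cyanophenyl in place of cyclopentyl on a saturated chain carbon bound to an aromatic carbon. The step most like this one is no change at the digits printed from compound 1 to compound 2 (within the scatter), where a phenyl bearing a fluorine took the same position with no change; the step of a 1.3-fold lower number from compound 1 to compound 3 (0.11 log units; within the scatter) and the step of a 1.3-fold lower number from compound 2 to compound 3 (0.11 log units; within the scatter) show that an open-chain branched group there also left the number where it was. Three different groups on that saturated chain carbon therefore gave one value, and a fourth aromatic group, now carrying a nitrile, is expected to behave the same way. The step of a 1.0-fold higher number from compound 1 to compound 4 (0.01 log units; within the scatter) is expected to stay within the scatter, with no direction beyond it. Compound 4 is estimated at 8 nM in this assay, between 3 nM and 20 nM.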

Compound 4, half-maximal effective concentration: 642 nM
Compound 4: middle estimate off by 80-fold (1.90 log units), on the low side; the whole stated range lies below it.
By their numbers in this assay, from the lowest: compounds 3, 1 and 2 (each within the scatter of the next); then compound 4.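

In this assay, among these compounds, the saturated chain carbon bound to an aromatic carbon proves far less permissive than the earlier compounds suggested: the 2-cyanophenyl group brings an 81-fold higher number from compound 1 to compound 4 (1.91 log units; beyond the scatter), a 100-fold higher number from compound 3 to compound 4 (2.02 log units; beyond the scatter) and an 81-fold higher number from compound 2 to compound 4 (1.91 log units; beyond the scatter), so the agreement among cyclopentyl, neopentyl and 3-fluorophenyl does not extend to every group placed there. The last of these steps matters most, since compound 2 also carries a six-membered aromatic ring of carbon only at this place, which shows that such a ring alone does not go with the large step and that the difference lies in how the ring is substituted. No measurement at hand bears on the cause of this large step.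

Going by these compounds, it remains open whether the large step follows the nitrile itself or its place on the ring, since 3-fluorophenyl and 2-cyanophenyl differ in both. A plain phenyl group, or a primary amide or methoxy group standing where the nitrile stands in 2-cyanophenyl, would be needed to tell how far the effect in this assay reaches.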